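From compound 3 to compound 4: a tert-butoxy swap

The compounds below may be only part of what the source reports. "The series", "measured", "known", "first", "only" and "open" are said of these compounds alone.

In a physicochemical assay for solubility, in phosphate buffer, with a stated time of 18 h, at pH 7.4 (on this read-out lower numbers stand for lower solubility and higher numbers for higher solubility), compound 1 `COc1cc2ncnc(-n3nc(-c4ccccn4)nc3N)c2cc1N` gives 3000 nM, compound 2 `COCCOc1cc2c(-n3nc(-c4ccccn4)nc3N)ncnc2cc1OC` gives 8000 nM and compound 3 `COc1cc2ncnc(-n3nc(-c4ccccn4)nc3N)c2cc1OCCCNC(=O)CN1C[C@@H](C)O[C@@H](C)C1` gives 34000 nM, the highest of the three. Compound 4 `COc1cc2ncnc(-n3nc(-c4ccccn4)nc3N)c2cc1OCCCNC(=O)OC(C)(C)C` carries tert-butoxy in place of (2,6-dimethylmorpholin-4-yl)methyl on a carbonyl carbon. Going by the values given here, the one measured step, a 2.7-fold higher number from compound 1 to compound 2 (0.43 log units; beyond the scatter), is a different change and offers only a rough, modest size. Compound 3 alone carries (2,6-dimethylmorpholin-4-yl)methyl, and without it compound 2 reaches 8000 nM, so a fall towards that level is expected. In this assay the expected change is a 6.8-fold lower number from compound 3 to compound 4 (0.83 log units; beyond the scatter), beyond the scatter. The estimate for compound 4 is 5000 nM, with an expected range from 1200 nM to 18000 nM.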

Compound 4, solubility: 2000 nM
Estimate against measurement, compound 4: 2.5-fold (0.40 log units) above; the measured number falls inside the stated range.
By their numbers in this assay, from the lowest: compounds 4 and 1 (each within the scatter of the next); then compound 2; then compound 3.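

In this assay, replacing (2,6-dimethylmorpholin-4-yl)methyl with tert-butoxy on this carbonyl carbon is a large step, a 17-fold lower number from compound 3 to compound 4 (1.23 log units; beyond the scatter), and the high number of compound 3 does not survive the swap. The carbamate-bearing chain also gives a modest step, a 4.0-fold lower number from compound 2 to compound 4 (0.60 log units; beyond the scatter), whereas the last step, a 1.5-fold lower number from compound 1 to compound 4 (0.18 log units; within the scatter), stays within the scatter. No evidence at hand bears on the cause of these steps.

As far as these compounds go, it remains open whether the high number needs the two methyl groups or the ring itself. Unsubstituted morpholin-4-ylmethyl or dimethylaminomethyl on the same carbonyl carbon would separate these.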